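Series notes: methyl added on the benzyloxy ring

This account rests on a few compounds, and the source may have more. Where it says the series, first, only, none or still open, it means among the compounds named here.

Compound 1 `CC(=O)Nc1ccc2c(c1)/C(=N\O)C(c1c[nH]c3ccc(NC(C)=O)cc13)=N2` gives 17900 nM in a functional assay on MGC-803 cells (Homo sapiens) for cytotoxicity, read by MTT assay, with a stated time of 2 days; a higher number here means a weaker inhibitor, a lower number a stronger inhibitor.
Compound 2 `Fc1ccc2c(c1)/C(=N\OCc1ccccc1)C(c1c[nH]c3ccc(F)cc13)=N2` gives 21300 nM in this assay.

Compound 2 holds the higher of the two numbers, but its gap to compound 1 lies within the scatter, so the two stand level. Compound 3 `Cc1ccc(CO/N=C2/C(c3c[nH]c4ccc(F)cc34)=Nc3ccc(F)cc32)cc1` differs from compound 2 by methyl in place of hydrogen on an aromatic carbon. Within the data shown here, no step between measured compounds sizes this change; in this assay no step beyond the scatter is expected in either direction. The expected step is a 1.1-fold lower number from compound 2 to compound 3 (0.03 log units; within the scatter). Compound 3 is estimated at 20000 nM, with a range from 8000 nM to 50000 nM.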

Compound 3, half-maximal inhibitory concentration: 20800 nM
Beside the measured number, compound 3's estimate is 1.0-fold (0.02 log units) below it, and the stated range covers the measured number.
By their numbers in this assay, from the lowest: compounds 1, 3 and 2 (each within the scatter of the next).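

In this assay, among these compounds, the change from benzyloxy to (4-methylbenzyl)oxy gives a 1.0-fold lower number from compound 2 to compound 3 (0.01 log units; within the scatter) and is the first sized step. Methyl in place of hydrogen on this aromatic carbon, para to a large group, thus leaves the number level with that of the unsubstituted benzyloxy compound. No measurement at hand bears on the reason for this.

Open, as far as these compounds go, is whether a carboxylic acid, an amine or a longer chain at this carbon would give a step beyond the scatter. Also open, from the compounds shown here alone, is how a methyl on another carbon of this ring would read.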